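The source may hold more compounds than are shown below. What is called first, only, known or untested is meant among the compounds shown, and "the series" means these compounds.

Measured so far in an assay on Sf9 cells for inhibition of protein deacetylase HDAC6 (Homo sapiens), read by fluorescence, with a stated time of 40 min, tested at 100 nM; on this read-out higher numbers stand for more inhibition at the one concentration tested (going by the name of the read-out) and lower numbers for less inhibition:

compound 1 `Cc1ccc(-c2nc(CNc3ccc(C(=O)NO)cc3)n(-c3ccccc3)n2)cc1` gives 62.2%
compound 2 `O=C(NO)c1ccc(NCc2nc(-c3ccco3)nn2-c2ccccc2)cc1` gives 59.9%
compound 3 `O=C(NO)c1ccc(NCc2nc(-c3cccc4cnccc34)nn2-c2ccccc2)cc1` gives 40.2%

Compound 3 stands lowest of the three numbers. Both steps down to it lie beyond the scatter: a number 22 percentage points lower from compound 1 to compound 3 (beyond the scatter) and a number 19.7 percentage points lower from compound 2 to compound 3 (beyond the scatter). By contrast the step of a number 2.3 percentage points lower from compound 1 to compound 2 (within the scatter) lies within the scatter, so the two smaller aromatic groups of compound 1 and compound 2 give much the same read-out, and isoquinolin-5-yl is what sets compound 3 apart.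

Compound 4 `COc1ccc(-c2nc(CNc3ccc(C(=O)NO)cc3)n(-c3ccccc3)n2)cc1` has not yet been measured. The change from compound 3 is 4-methoxyphenyl in place of isoquinolin-5-yl on an aromatic carbon. Among the compounds with values here, this undoes the one change that lowered the number in the two measured steps, and the group that enters, 4-methoxyphenyl, is of the same kind as the 4-methylphenyl of compound 1. The two steps that bear on it, each a modest step downward when isoquinolin-5-yl came in, are therefore expected to run in reverse: a modest step upward in this assay, beyond the scatter, bringing compound 4 back toward compound 1 and compound 2.

Compound 4 is estimated at 60%, with a range from 45% to 72%, which means an expected step of a number 19.8 percentage points higher from compound 3 to compound 4 (beyond the scatter).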

Compound 4, a percentage reported as inhibition, at one concentration (the size of the read-out at that concentration, not a potency): 77.6%
The estimate for compound 4 lay 17.6 percentage points below the measured number; the whole stated range lies below it.
By their numbers in this assay, from the lowest: compound 3; then compounds 2 and 1 (each within the scatter of the next); then compound 4.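

Within the data shown here, at this aromatic carbon of the five-membered ring, the earlier compounds showed only that 4-methylphenyl and furan-2-yl gave much the same read-out while isoquinolin-5-yl fell away; in this assay, methoxy in place of methyl on the outer phenyl ring gives a number 15.4 percentage points higher from compound 1 to compound 4 (beyond the scatter), so the read-out also answers to a small change on the ring that sits at this carbon. The 4-methoxyphenyl group also stands clear of the five-membered furan-2-yl, with a number 17.7 percentage points higher from compound 2 to compound 4 (beyond the scatter), and of the two-ring isoquinolin-5-yl, with a number 37.4 percentage points higher from compound 3 to compound 4 (beyond the scatter), the widest step among these compounds. Isoquinolin-5-yl and 4-methoxyphenyl carry the same count of hydrogen-bond acceptors, so that count alone does not separate compound 3 from compound 4.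

Nothing at hand gives a reason for these steps.

As far as these compounds go, whether the rise continues with an ethoxy group or a dimethylamino group in place of the methoxy remains open, as does what a hydroxy group would do there. The read-out comes from a single concentration and a single enzyme, so the potency of these compounds and their action on other deacetylases also stay open.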